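Swapping a Hydroxyphenyl Arm on a Shared Core

The source may hold more compounds than are shown below. What is called first, only, known or untested is meant among the compounds shown, and "the series" means these compounds.

Compound 1, `Oc1cccc(-c2cc(-c3cccc(C(F)(F)F)c3)cc(-c3cccc(O)c3)n2)c1`: in a functional assay on DU-145 cells (Homo sapiens) for inhibition (on this read-out higher numbers stand for weaker inhibition and lower numbers for stronger inhibition), compound 1 reaches only the assay limit of > 50000 nM.
Compound 2, `Oc1ccc(-c2cc(-c3cccc(C(F)(F)F)c3)cc(-c3cccc(O)c3)n2)cc1`: in this assay compound 2 gives 11100 nM.
Compound 3, `Oc1cccc(-c2cc(-c3ccccc3OC(F)(F)F)cc(-c3ccccc3O)n2)c1`: in this assay compound 3 reaches only the assay limit of > 50000 nM.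

Two of the three values sit at the limit, as the limit of > 50000 nM in this assay, at which 2 of the 3 values shown sit, shows. Among the compounds with values here, the one measured step, an at least 4.5-fold lower number from compound 1 to compound 2 (0.65 log units; beyond the scatter), follows the change (4-hydroxyphenyl in place of 3-hydroxyphenyl on an aromatic carbon). Compound 4, `Oc1ccc(-c2cc(-c3ccccc3OC(F)(F)F)cc(-c3ccccc3O)n2)cc1`, is not yet measured and arises from compound 3 by the same kind of change, (4-hydroxyphenyl in place of 3-hydroxyphenyl on an aromatic carbon). Around the place the surroundings differ: in compound 4 the new arm is meta to a 2-hydroxyphenyl group and meta to a large group, whereas in compound 2 it is meta to a 3-(trifluoromethyl)phenyl group and meta to a 3-hydroxyphenyl group. How the cores of compound 1 and compound 3 differ is not broken down here. Resting on an at least 4.5-fold lower number from compound 1 to compound 2 (0.65 log units; beyond the scatter), a step of roughly that size is expected, an at least 2.0-fold lower number from compound 3 to compound 4 (0.30 log units; that floor lies within the scatter), although a limit may again be reported. Compound 4 is therefore estimated at about 25000 nM, between 8000 nM and 50000 nM.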

Compound 4, half-maximal inhibitory concentration: 4190 nM
Compound 4: middle estimate off by 6.0-fold (0.78 log units), on the high side, and the stated range ends above it.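

In this assay, the swap of 3-hydroxyphenyl for 4-hydroxyphenyl carries over to a second core, with an at least 11-fold lower number from compound 3 to compound 4 (1.07 log units; beyond the scatter), so stronger inhibition follows this change on both cores shown. This does not show that the change is worth the same on each core, since the two steps cannot be told apart in size: the same change on two cores in this assay, an at least 4.5-fold lower number (0.65 log units; beyond the scatter) from compound 1 to compound 2 and an at least 11-fold lower number (1.07 log units; beyond the scatter) from compound 3 to compound 4; the limit leaves it open whether they differ. Compound 1 and compound 3 each stand at a limit rather than at a number, and two cores cannot establish a rule for the whole series: the limit of > 50000 nM in this assay, at which 2 of the 4 values shown sit.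

Going by these compounds, it remains open whether the gain would survive if an amine or a carboxylic acid replaced the hydroxyl on the 4-hydroxyphenyl arm. On these data alone, it is equally open whether it would hold on cores carrying other groups, such as a longer alkyl chain.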